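A few compounds are considered here, and "the series" means these few. Any claim that something is new, unique, unknown or untested is made for them only; others in the source may bear on it.

Compound 1 `CCCCCCCCOC(=O)CN(C)C(=N)N` anchors the series: in an ADME assay (Rattus norvegicus) for activation, read by fluorescence, with a stated time of 60 min, tested at 1 ug/mL (a higher number here means that the compound crosses the layer faster, a lower number that the compound crosses the layer more slowly), compound 1 gives 0.93 10^-6 cm/s. Compound 2 `CCCCCCCCCCCCCCCCCCOC(=O)CN(C)C(=N)N` carries the longest chain, but in this assay compound 2 is recorded only as "not determined" (no result reported), with no number returned, so it offers no reference point of its own. Compound 3 `CCCCCCCCCOC(=O)CN(C)C(=N)N` is next for this assay. Against compound 2 the change is hydrogen in place of nonyl on a saturated chain carbon, nine bonds along the chain from an oxygen next to a carbonyl group. Among the measured compounds shown here, no step between measured compounds is known, so compound 3 is expected to land near compound 1 at 0.93 10^-6 cm/s, with any difference within the scatter rather than a step of real size in either direction. Compound 3 is estimated at 1 10^-6 cm/s, within 0.4 10^-6 cm/s to 2.5 10^-6 cm/s.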

Compound 3, apparent permeability in the Rattus norvegicus assay: 1.49 10^-6 cm/s
Beside the measured number, compound 3's estimate is 1.5-fold (0.17 log units) below it, and the stated range covers the measured number.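

In the Rattus norvegicus assay, methyl in place of hydrogen at this position gives a 1.6-fold higher number from compound 1 to compound 3 (0.20 log units; within the scatter), so this small change in the chain does not separate the two compounds on that read-out. In a physicochemical assay for lipophilicity (on this read-out lower numbers stand for lower lipophilicity and higher numbers for higher lipophilicity), compound 2 gives 5.59 and compound 3 gives 2.47, so hydrogen in place of nonyl is a large step on that read-out. The same step in the Rattus norvegicus assay cannot be read.

Open, on these data alone, is whether a decyl chain in place of nonyl, or a carboxylic acid on the chain, would move the number in the Rattus norvegicus assay beyond the scatter.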